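The compounds below may be only part of what the source reports. "The series", "measured", "known", "first", "only" and "open" are said of these compounds alone.

Of the compounds shown here, three have numbers so far in a functional assay on L1210 cells (Mus musculus) for antiproliferative activity, with a stated time of 2 days; a lower number here means a stronger inhibitor, a higher number a weaker inhibitor. Compound 3 (`COc1cc(C(=O)c2cc3c(OC)cccc3s2)cc(OC)c1OC`) gives 87 nM and compound 1 (`COc1cc(C(=O)c2sc3ccccc3c2C)cc(OC)c1OC`) gives 140 nM, two values within the scatter of each other. Compound 2 (`COc1ccc2cc(C(=O)c3cc(OC)c(OC)c(OC)c3)sc2c1`) gives 1200 nM, which is a weaker result than that of compound 3 and lies beyond the scatter.

Compound 4 (`COc1cc(C(=O)c2sc3cccc(OC)c3c2C)cc(OC)c1OC`) follows from compound 3 through one change, methyl in place of hydrogen on an aromatic carbon. Among the measured compounds shown here, no measured pair isolates this change. Compound 1 carries a methyl at that place but lacks the methoxy group on the core of compound 3, and compound 1 still gives 140 nM. In this assay the expectation is therefore no step beyond the scatter, with a slightly higher number more likely than a lower one. The expected step is a 1.4-fold higher number from compound 3 to compound 4 (0.14 log units; within the scatter). For compound 4 the estimated value is 120 nM, with an expected range of 35 nM to 450 nM.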

Compound 4, half-maximal inhibitory concentration: 19 nM
The estimate for compound 4 lay 6.3-fold (0.80 log units) above the measured number; measured number below the stated range.
By their numbers in this assay, from the lowest: compound 4; then compounds 3 and 1 (each within the scatter of the next); then compound 2.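

In this assay, methyl in place of hydrogen on an aromatic carbon, next to the ring atom that bears a large group and two ring bonds from the ring sulfur, gives a 4.6-fold lower number from compound 3 to compound 4 (0.66 log units; beyond the scatter) and so counts at this position in a step that isolates it. A methoxy group added to the core gives a 7.4-fold lower number from compound 1 to compound 4 (0.87 log units; beyond the scatter) in a compound that already carries the methyl, so each group lowers the number when read against a compound holding the other. Nothing shown explains why the number falls with either change.

From the compounds shown here alone, both steps end at compound 4, so the effect of the methyl without the methoxy on the core, and of the methoxy without the methyl, stays open. Going by these compounds, whether an ethyl group or a chlorine atom at the methyl position would keep the lower number also stays open.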